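Swapping a dihydroxypropyl amide for a cyclobutyl amide

This account rests on a few compounds, and the source may have more. Where it says the series, first, only, none or still open, it means among the compounds named here.

Of the compounds shown here, three built on a shared core have been tested in a functional assay on OVCAR-8 cells (Homo sapiens) for antiproliferative activity; on this read-out lower numbers stand for stronger inhibition and higher numbers for weaker inhibition. Compound 1 `Cn1ncc(Cl)c1-c1cc(C(=O)N[C@@H]2CN[C@H](CCN3CCC(O)CC3)C[C@H]2c2ccc(Cl)c(Cl)c2)oc1Cl` gives 15900 nM. Compound 2 `Cn1ncc(Cl)c1-c1cc(C(=O)N[C@@H]2CN[C@H](CC(N)=O)C[C@H]2c2ccc(Cl)c(Cl)c2)oc1Cl` gives 1000 nM. Compound 3 `Cn1ncc(Cl)c1-c1cc(C(=O)N[C@@H]2CN[C@H](CC(=O)NCC(O)CO)C[C@H]2c2ccc(Cl)c(Cl)c2)oc1Cl` gives 5900 nM, which places it second highest of the three: the step of a 2.7-fold lower number from compound 1 to compound 3 (0.43 log units; beyond the scatter) is modest, while the step of a 5.9-fold higher number from compound 2 to compound 3 (0.77 log units; beyond the scatter) is also modest. Compound 4 `Cn1ncc(Cl)c1-c1cc(C(=O)N[C@@H]2CN[C@H](CC(=O)NC3CCC3)C[C@H]2c2ccc(Cl)c(Cl)c2)oc1Cl` has not yet been measured; it differs from compound 3 in one place: cyclobutyl in place of 2,3-dihydroxypropyl on an amide-type nitrogen.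

For the measured compounds named here, of the measured steps, a 5.9-fold higher number from compound 2 to compound 3 (0.77 log units; beyond the scatter) bears most directly on this change, since it shows what adding 2,3-dihydroxypropyl to the amide nitrogen did; no measured pair shows a carbon-only ring on that nitrogen. Compound 4 is expected to land between compound 2 and compound 3, and the estimate for this assay is 3000 nM, with a range from 800 nM to 12000 nM. The step expected from compound 3 to compound 4 is thus a 2.0-fold lower number from compound 3 to compound 4 (0.29 log units; within the scatter), and a result within the scatter of compound 3 would not be surprising.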

Compound 4, half-maximal inhibitory concentration: 610 nM
Beside the measured number, compound 4's estimate is 4.9-fold (0.69 log units) above it, and the stated range ends above it.
By their numbers in this assay, from the lowest: compounds 4 and 2 (each within the scatter of the next); then compound 3; then compound 1.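

In this assay, the amide nitrogen accepts a carbon-only ring without a shift beyond the scatter: the step is a 1.6-fold lower number from compound 2 to compound 4 (0.21 log units; within the scatter), so cyclobutyl leaves the number level with that of the unsubstituted amide, which 2,3-dihydroxypropyl did not do. The direct exchange of these two groups gives a 9.7-fold lower number from compound 3 to compound 4 (0.99 log units; beyond the scatter), which shows that the earlier rise does not follow from substitution on this nitrogen as such, but goes with 2,3-dihydroxypropyl in particular. Putting cyclobutylcarbamoyl in place of (4-hydroxypiperidin-1-yl)methyl gives a 26-fold lower number from compound 1 to compound 4 (1.42 log units; beyond the scatter), the largest step among these compounds.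

Nothing available here accounts for the difference between the two groups on the nitrogen. On these data alone, it remains open whether a cyclohexyl ring, a straight butyl chain or a carboxylic acid on that same nitrogen would stay level with compound 4.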